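A Small Amino Group Replaces 4-Methylphenyl

A few compounds are considered here, and "the series" means these few. Any claim that something is new, unique, unknown or untested is made for them only; others in the source may bear on it.

In a functional assay on MCF7 cells (Homo sapiens) for cytotoxicity, read by sulforhodamine B assay, with a stated time of 24 h (a higher number here means a weaker inhibitor, a lower number a stronger inhibitor), compound 1 `Cc1ccc(/N=C2\C(=O)Nc3ccc(S(=O)(=O)N4CCOCC4)cc32)cc1` gives 55900 nM as its measured value. Compound 2 `O=C1Nc2ccc(S(=O)(=O)N3CCOCC3)cc2/C1=N/c1cccc(C(F)(F)F)c1` gives 41100 nM in the same test, and compound 3 `CC(=O)N/N=C1\C(=O)Nc2ccc(S(=O)(=O)N3CCOCC3)cc21` gives 56000 nM there too. Compound 1 therefore stands among three numbers that repeated measurements could not tell apart.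

Compound 4 `N/N=C1\C(=O)Nc2ccc(S(=O)(=O)N3CCOCC3)cc21` has not yet been measured. It carries amino in place of 4-methylphenyl on a double-bonded nitrogen and keeps the core of compound 1 unchanged.

Two measured steps alter that same place. Putting 3-(trifluoromethyl)phenyl there gives a 1.4-fold lower number from compound 1 to compound 2 (0.13 log units; within the scatter) as the result, while putting acetamido there gives a 1.0-fold higher number from compound 1 to compound 3 (0.00 log units; within the scatter) as the result. Going by these compounds, neither step leaves the scatter, although amino itself remains untested, so no clear step in either direction is expected in this assay for this change. The estimate means a 1.1-fold lower number from compound 1 to compound 4 (0.05 log units; within the scatter) as the expected step. For compound 4 the estimated value is 50000 nM within an expected range from 24000 nM to 100000 nM in this test.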

Compound 4, half-maximal inhibitory concentration: 46800 nM
Compound 4: the middle estimate sits 1.1-fold (0.03 log units) above what was measured; low and high end bracket the measured number.
By their numbers in this assay, from the lowest: compounds 2, 4, 1 and 3 (each within the scatter of the next).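

Amino drops the ring of 4-methylphenyl altogether, and in this assay this change still gives only a 1.2-fold lower number from compound 1 to compound 4 (0.08 log units; within the scatter). Taking the acetyl off the acetamido group gives a 1.2-fold lower number from compound 3 to compound 4 (0.08 log units; within the scatter), and amino in place of 3-(trifluoromethyl)phenyl gives a 1.1-fold higher number from compound 2 to compound 4 (0.06 log units; within the scatter). All four groups on the double-bonded nitrogen now read alike, so even this stripped-down group produces no step beyond the scatter at this position, and no measurement at hand explains that flat result.

Going by these compounds, whether a carboxylic acid or a longer alkyl chain on the double-bonded nitrogen would shift the number beyond the scatter remains open. So does whether a change elsewhere on the shared core would matter more than any change at this position.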